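Removing the Phenoxy Group from Compound 2

A few compounds are considered here, and "the series" means these few. Any claim that something is new, unique, unknown or untested is made for them only; others in the source may bear on it.

In a functional assay on MCF7 cells (Homo sapiens) for inhibition, read by resazurin assay, with a stated time of 72 h (on this read-out higher numbers stand for weaker inhibition and lower numbers for stronger inhibition), compound 1 (`COc1cc(N2C(=O)CC2c2ccc(SC)cc2)cc(OC)c1OC`) gives 67 nM. Compound 2 (`CCOc1ccc(C2C(Oc3ccccc3)C(=O)N2c2cc(OC)c(OC)c(OC)c2)cc1`) gives 69 nM, so the two sit level within the usual scatter of repeated measurements. Compound 3 (`CCOc1ccc(C2CC(=O)N2c2cc(OC)c(OC)c(OC)c2)cc1`) has not yet been measured. It carries hydrogen in place of phenoxy on a saturated ring carbon. Going by the values given here, no measured pair yet shows what such a swap does, so only a modest shift toward weaker inhibition is expected in this assay, and the estimated change is a 1.9-fold higher number from compound 2 to compound 3 (0.28 log units; within the scatter). Compound 3 is estimated at 130 nM, with an expected range of 40 nM to 450 nM.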

Compound 3, half-maximal inhibitory concentration: 64 nM
The estimate for compound 3 lay 2.0-fold (0.31 log units) above the measured number; measured number inside the range.
By their numbers in this assay, from the lowest: compounds 3, 1 and 2 (each within the scatter of the next).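

In this assay the step from phenoxy to hydrogen on the saturated ring carbon is a 1.1-fold lower number from compound 2 to compound 3 (0.03 log units; within the scatter) and so shows that phenoxy is not needed at this position to keep the number. The swap of methylsulfanyl for ethoxy on an aromatic carbon, seen in a 1.0-fold lower number from compound 1 to compound 3 (0.02 log units; within the scatter) and read in the same assay, also leaves the numbers level. Nothing at hand explains why either change leaves the number level. On these data alone, whether an amine or a carboxylic acid on this saturated ring carbon would also keep the number stays open. So does the effect of a longer chain in place of ethoxy.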